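A few compounds are considered here, and "the series" means these few. Any claim that something is new, unique, unknown or untested is made for them only; others in the source may bear on it.

Among the compounds with values here, compound 1, `Fc1ccc2c(c1CNc1ncc(Oc3ccccc3)c3nncn13)CCO2`, is the most lipophilic of the three compounds measured so far. In a physicochemical assay for lipophilicity, using the shake flask method, in phosphate buffer, measured as octanol-water partition, with a stated time of 30 min, at pH 7.4 (a lower number here means a more polar compound, a higher number a more lipophilic compound), compound 1 gives 3.5. Compound 3, `Cc1ncccc1-c1cnc(NCc2c(F)ccc3c2CCO3)c2ncc(=O)[nH]c12`, gives 2.8 in this assay, and compound 2, `Cn1nccc1-c1cnc(NCc2c(F)ccc3c2CCO3)c2cn[nH]c(=O)c12`, gives 2.6. Compound 1 stands highest of the three numbers: its nearest neighbour is compound 3, a number beyond the scatter below it, and the furthest is compound 2, also beyond the scatter below it. No pair among these three differs in only one place, so no single step can be read from them.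

Compound 4, `O=C(Nc1cnc(NCc2c(F)ccc3c2CCO3)n2cnnc12)c1cccnc1`, has not yet been measured in this assay. It differs from compound 1 in one place: ((pyridin-3-yl)carbonyl)amino in place of phenoxy on an aromatic carbon. Given where compound 1 stands, the step from compound 1 to compound 4 is expected to go downward and to be beyond the scatter, at a number 1.30 log units lower from compound 1 to compound 4 (beyond the scatter). Compound 4 is therefore estimated to give 2.2 in this assay, within a range from 1.6 to 2.8.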

Compound 4, distribution coefficient: 2
Beside the measured number, compound 4's estimate is 0.20 log units above it, within the range that was stated.
By their numbers in this assay, from the lowest: compound 4; then compounds 2 and 3 (each within the scatter of the next); then compound 1.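

Within the data shown here, the exchange of phenoxy for ((pyridin-3-yl)carbonyl)amino on an aromatic carbon of a six-membered aromatic ring with 2 nitrogen gives a number 1.50 log units lower from compound 1 to compound 4 (beyond the scatter) and is the first change in one place that can be read in this assay at all. With the rest of compound 1 kept, the entering group differs in several counted ways at once: a ring with 1 hetero atom, a double bond outside aromatic rings, 1 hydrogen-bond donor and 2 hydrogen-bond acceptors, so this single step cannot be divided among them. Nothing measured here accounts for the size of the step. The compounds shown leave open how much of it belongs to the carbonylamino link and how much to the pyridine ring. They also leave open how a benzoylamino group, a simple amine or a carboxylic acid would read at this position.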